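A few compounds are considered here, and "the series" means these few. Any claim that something is new, unique, unknown or untested is made for them only; others in the source may bear on it.

Measured compounds in an assay on cells for displacement of a labelled ligand from Glucagon receptor (Homo sapiens), in the presence of a further agent that is not named here; on this read-out higher numbers stand for weaker inhibition and lower numbers for stronger inhibition:
- compound 1 `CCCC(Oc1ccc(-n2cc(OC)cn2)cc1)c1ccc(C(=O)NCCC(=O)O)cc1`: 4400 nM
- compound 2 `O=C(O)CCNC(=O)c1ccc(C(Oc2ccc(-n3cc(C(F)(F)F)cn3)cc2)C2CCC2)cc1`: 700 nM
- compound 3 `CCCC(Oc1ccc(-n2cc(C(F)(F)F)c(C)n2)cc1)c1ccc(C(=O)NCCC(=O)O)cc1`: 1100 nM

Compound 2 sits at the lower end of these numbers; its value and that of compound 3 lie within the usual scatter of each other, whereas compound 1 stands well apart from both. Among the measured compounds shown here, the only single-point step in the set, a 4.0-fold lower number from compound 1 to compound 3 (0.60 log units; beyond the scatter), concerns the pyrazolyl group and not the saturated chain carbon bound to an aromatic carbon and an oxygen on an aromatic ring.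

Compound 4 `CC(C)CC(Oc1ccc(-n2cc(C(F)(F)F)cn2)cc1)c1ccc(C(=O)NCCC(=O)O)cc1` is compound 2 with isobutyl in place of cyclobutyl on a saturated chain carbon bound to an aromatic carbon and an oxygen on an aromatic ring. For the measured compounds named here, no measured pair varies this position alone: compounds 1 and 3 carry propyl there, compound 2 cyclobutyl, and the pyrazolyl group differs in every such comparison, so the pyrazolyl step cannot be carried over to the chain. What the numbers do show is that a propyl analogue with a differently substituted pyrazolyl group, compound 3, gives 1100 nM, close to the value of compound 2. The expectation for the cyclobutyl-to-isobutyl change is therefore a step of a 1.3-fold higher number from compound 2 to compound 4 (0.11 log units; within the scatter) that stays within the scatter, with no direction claimed. Compound 4 is estimated at 900 nM in this assay, with a range from 400 nM to 2200 nM.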

Compound 4, inhibition constant: 549 nM
For compound 4 the middle estimate is 1.6-fold (0.21 log units) above the measured one, within the range that was stated.
By their numbers in this assay, from the lowest: compounds 4, 2 and 3 (each within the scatter of the next); then compound 1.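

In this assay, among the compounds shown here, compounds 2 and 4 form the first pair that varies only the group on a saturated chain carbon bound to an aromatic carbon and an oxygen on an aromatic ring, and a 1.3-fold lower number from compound 2 to compound 4 (0.11 log units; within the scatter) places the two compounds within the scatter of each other. With the pyrazolyl group these two compounds share, replacing cyclobutyl with isobutyl, each of 4 heavy atoms, removes the four-membered ring without separating the two values, so that ring is not required for a value in this range. No measurement on hand bears on the reason for this result.

For the compounds shown here, whether the same holds with the other pyrazolyl groups of compounds 1 and 3 stays open, as this pair covers a single pyrazolyl group and only two groups at this position. Also open, as far as these compounds go, is how a cyclohexyl ring, a longer chain such as pentyl, or a chain carrying an amine at this position would compare with cyclobutyl and isobutyl.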